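Replacing 4-acetylphenyl with 4-nitrobenzyl: what to expect

A few compounds are considered here, and "the series" means these few. Any claim that something is new, unique, unknown or untested is made for them only; others in the source may bear on it.

The four compounds here share one core and differ in the group carried on an aromatic nitrogen. In a functional assay on IMR-32 cells (Homo sapiens) for antiproliferative activity, read by MTT assay (on this read-out higher numbers stand for weaker inhibition and lower numbers for stronger inhibition), compound 1 `CC1(C)CCc2cc(C(=O)/C=C/c3ccc(OCc4cn(-c5ccc(Cl)cc5)nn4)cc3)c(O)cc2O1` gives 92100 nM, and compound 2 `CC1(C)CCc2cc(C(=O)/C=C/c3ccc(OCc4cn(-c5ccc(Br)cc5)nn4)cc3)c(O)cc2O1` gives 69400 nM. Compound 3 `CC(=O)c1ccc(-n2cc(COc3ccc(/C=C/C(=O)c4cc5c(cc4O)OC(C)(C)CC5)cc3)nn2)cc1` has no number: it is recorded as "not active" (no number reported), so it cannot be placed on the numerical scale of this assay.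

Moving on from compound 3, compound 4 `CC1(C)CCc2cc(C(=O)/C=C/c3ccc(OCc4cn(Cc5ccc([N+](=O)[O-])cc5)nn4)cc3)c(O)cc2O1` carries 4-nitrobenzyl in place of 4-acetylphenyl on an aromatic nitrogen. Among the measured compounds shown here, only one measured step is available, bromo in place of chloro on an aromatic carbon, and it is a 1.3-fold lower number from compound 1 to compound 2 (0.12 log units; within the scatter). That step is a different exchange, so it gives no direct size for this one. With no number for compound 3 as a starting point, neither a size nor a direction of change in this assay can be stated. The expectation therefore leans on the two measured relatives, compound 1 at 92100 nM and compound 2 at 69400 nM. A result without a number, as for compound 3, also remains quite possible. Compound 4 is expected at about 80000 nM, with an estimated range from 30000 nM to 200000 nM.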

Compound 4, half-maximal inhibitory concentration: 108000 nM
Beside the measured number, compound 4's estimate is 1.4-fold (0.13 log units) below it, within the range that was stated.
By their numbers in this assay, from the lowest: compounds 2, 1 and 4 (each within the scatter of the next).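

Exchanging 4-bromophenyl or 4-chlorophenyl for 4-nitrobenzyl gives a 1.6-fold higher number from compound 2 to compound 4 (0.19 log units; within the scatter) and a 1.2-fold higher number from compound 1 to compound 4 (0.07 log units; within the scatter) and so stays within the scatter in this assay. Among the compounds shown here, until now the only measured step at this position, on an aromatic nitrogen of the five-membered ring, was a swap of one halogen for another on the same phenyl ring, whereas this result shows that a much larger exchange of the group, with a benzyl in place of a phenyl and a nitro group in place of a halogen, still leaves compounds 1, 2 and 4 within the scatter of one another, while compound 3 remains recorded as "not active" (no number reported) and has no number to set beside them. Nothing available here explains these results.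

The shown compounds do not separate the part played by the benzyl from that played by the nitro group, a question that a pair such as 4-nitrophenyl and 4-chlorobenzyl could address. Also open, going by these compounds, is whether a group of another kind on this nitrogen, such as an amine, a carboxylic acid or a longer chain, would give a number clearly apart from these.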